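Swapping the aryl group in a cytotoxic oxindole series

This account rests on a few compounds, and the source may have more. Where it says the series, first, only, none or still open, it means among the compounds named here.

Of the compounds shown here, three share one core and have been tested in a functional assay on KB cells (Homo sapiens) for cytotoxicity, read by MTT assay, with a stated time of 72 h; on this read-out lower numbers stand for an effect already at smaller amounts and higher numbers for an effect only at larger amounts of compound. Among the measured compounds shown here, compound 1 `Cc1ccc2nc(Cl)c(/C=C3\C(=O)N(c4c(Cl)cccc4Cl)c4ccccc43)cc2c1C` gives 10 ug/mL, while compound 2 `Cc1ccc2nc(Cl)c(/C=C3\C(=O)N(c4c(Cl)cccc4Cl)c4ccccc43)cc2c1` gives 100 ug/mL; the single change between them is a 10-fold higher number from compound 1 to compound 2 (1.00 log units; beyond the scatter). Compound 3 `CN(C)c1ccc(/C=C2\C(=O)N(c3c(Cl)cccc3Cl)c3ccccc32)cc1` gives 15 ug/mL, which places it between the other two: close to compound 1, within the usual scatter, and clearly apart from compound 2.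

Compound 4 `O=C1/C(=C\c2ccccc2Cl)c2ccccc2N1c1c(Cl)cccc1Cl` has not yet been measured. It differs from compound 3 in one place: 2-chlorophenyl in place of 4-(dimethylamino)phenyl on a double-bonded chain carbon bound to a double-bonded ring carbon. For the measured compounds named here, none of the measured steps touches this position, since the only step on record changes a methyl on the other aromatic part of the core; it therefore gives no direct guidance on the size or direction of the step here. Going by the values given here, what is known is only that the three measured values span a range from compound 1 to compound 2, and that replacing the whole aryl group is a larger change than any step seen so far.

Compound 4 is therefore expected to fall somewhere within that measured range, with a 2.0-fold higher number from compound 3 to compound 4 (0.30 log units; within the scatter) as the estimated step, the middle estimate being 30 ug/mL and the plausible span running from 8 ug/mL to 120 ug/mL.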

Compound 4, concentration for half-maximal effect: 5 ug/mL
Beside the measured number, compound 4's estimate is 6.0-fold (0.78 log units) above it; the measured number lies below the stated range.
By their numbers in this assay, from the lowest: compounds 4, 1 and 3 (each within the scatter of the next, the first and the last beyond it); then compound 2.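

In this assay, the group on a double-bonded chain carbon bound to a double-bonded ring carbon clearly influences the read-out: putting 2-chlorophenyl in place of 4-(dimethylamino)phenyl gives a 3.0-fold lower number from compound 3 to compound 4 (0.48 log units; beyond the scatter). The position therefore accepts an aryl group without a dimethylamino group, and here the number falls rather than rises. No measurement shown here explains the size or direction of this step.

On these data alone, the swap changes two things at once, removing the dimethylamino group and bringing in a chlorine, so the contribution of each stays open. An unsubstituted phenyl or a 4-chlorophenyl group would help to separate the two, while a carboxylic acid or a morpholine on the ring would show how far other groups are accepted at this position.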